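Cyclohexyl in place of cyclopropyl: an unmeasured step

The source may report more compounds than this note shows. Statements on the series, on what has been measured and on what is new or still open speak of the compounds shown alone.

Measured in an ADME assay on liver (Homo sapiens) for metabolic stability, read by LC-MS, using microsomes and NADPH; a lower number here means that less of the compound is left, a higher number that more of the compound is left:
compound 1 `CCCN(Cc1ccc(OCCN2C(=O)CCC2=O)c(C)c1)[C@@H](CC(=O)O)c1ccc(Cl)cc1`: 97%
compound 2 `Cc1cc(CN(CC2CC2)C(CC(=O)O)c2ccc(Cl)cc2)ccc1OCCN1C(=O)CCC1=O`: 96%
compound 3 `Cc1cc(CN(CC2CCCC2)[C@@H](CC(=O)O)c2ccc(Cl)cc2)ccc1OCCN1C(=O)CCC1=O`: 78%

Compound 2 stands level with compound 1, within the scatter, and above compound 3 by a gap beyond the scatter. Compound 4 `Cc1cc(CN(CC2CCCCC2)C(CC(=O)O)c2ccc(Cl)cc2)ccc1OCCN1C(=O)CCC1=O`, not yet measured, differs from it by cyclohexyl in place of cyclopropyl on a saturated chain carbon bound to an amine nitrogen, with cyclohexyl in place of cyclopropyl on a saturated chain carbon bound to an amine nitrogen. Going by the values given here, the one measured step that bears on this is a number 19 percentage points lower from compound 1 to compound 3 (beyond the scatter), a modest change that brings in cyclopentyl. Among the compounds with values here, no measured step covers cyclohexyl itself, so the reasoning stays uncertain. A similar fall is therefore expected in this assay, and the estimated step is a number 22 percentage points lower from compound 2 to compound 4 (beyond the scatter) in this reading. For compound 4 the expected value is 74%, with an estimated range from 55% to 90% for the measurement.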

Compound 4, percent of the compound remaining: 47%
The estimate for compound 4 lay 27 percentage points above the measured number; the measured number lies below the stated range.
By their numbers in this assay, from the lowest: compound 4; then compound 3; then compounds 2 and 1 (each within the scatter of the next).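

In this assay, cyclohexyl in place of cyclopropyl on a saturated chain carbon bound to an amine nitrogen gives a number 49 percentage points lower from compound 2 to compound 4 (beyond the scatter), a large step, where cyclopentyl gave only the modest a number 19 percentage points lower from compound 1 to compound 3 (beyond the scatter). The earlier compounds shown here showed a fall at this position but not how steep it can become with a six-membered ring. Nothing at hand explains the size of this fall. From the compounds shown here alone, it remains open whether a tetrahydropyranyl or a phenyl group at this place would behave like cyclohexyl or stay closer to cyclopropyl.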